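The compounds below may be only part of what the source reports. "The series", "measured", "known", "first", "only" and "open" are said of these compounds alone.

In a functional assay on the whole organism (Tail) with Rattus norvegicus as the target, in the tail flick test, with a stated time of 60 min, at a dose of 25 mg/kg by the oral route (a higher number here means more inhibition at the dose given (going by the name of the read-out), a lower number less inhibition), three compounds built on one shared core have been measured. Compound 1 `CC(=O)N1N=C(c2ccc(F)cc2)CC1c1cn(-c2ccccc2)nc1-c1ccc(F)cc1` gives 43%. Compound 2 `CC(=O)N1N=C(c2ccc(F)cc2)CC1c1cn(-c2ccccc2)nc1-c1ccc(Cl)cc1` gives 44%. Compound 3 `COc1ccc(-c2nn(-c3ccccc3)cc2C2CC(c3ccc(F)cc3)=NN2C(C)=O)cc1` gives 66%, the highest of the three numbers. The step of a number 1 percentage points higher from compound 1 to compound 2 (within the scatter) shows that swapping one halogen for the other changes nothing that can be trusted. The steps of a number 23 percentage points higher from compound 1 to compound 3 (beyond the scatter) and a number 22 percentage points higher from compound 2 to compound 3 (beyond the scatter) show that the methoxy group goes with a modest gain over either halogen.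

Compound 4 `CC(=O)N1N=C(c2ccc(F)cc2)CC1c1cn(-c2ccccc2)nc1-c1cccc([N+](=O)[O-])c1` has not yet been measured. It differs from compound 3 by 3-nitrophenyl in place of 4-methoxyphenyl on an aromatic carbon. Going by the values given here, no measured step involves a nitro group, so the only guide is that the methoxy group, once removed, has so far meant a lower number, as the reverse of a number 23 percentage points higher from compound 1 to compound 3 (beyond the scatter) would show. A fall toward the numbers of compound 1 and compound 2 is expected, so compound 4 is estimated to show a step of a number 18 percentage points lower from compound 3 to compound 4 (beyond the scatter). The estimate for compound 4 is 48%, in a range from 32% to 64%.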

Compound 4, a percentage reported as inhibition, in the whole organism at one dose (the size of the read-out at that dose, not a potency): 109%
Compound 4: middle estimate off by 61 percentage points, on the low side, outside the stated range (above it).
By their numbers in this assay, from the lowest: compounds 1 and 2 (each within the scatter of the next); then compound 3; then compound 4.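

In this assay, going by these compounds alone, placing 3-nitrophenyl in place of 4-methoxyphenyl gives a number 43 percentage points higher from compound 3 to compound 4 (beyond the scatter), so the best group among the earlier compounds is not the limit at this position. The same group also gives large steps against the halogen-bearing rings, with a number 65 percentage points higher from compound 2 to compound 4 (beyond the scatter) and a number 66 percentage points higher from compound 1 to compound 4 (beyond the scatter), which shows that this position can carry a much wider spread of numbers than the first three compounds revealed. Nothing available here explains why the number rises so far.

This change replaces the group on the phenyl ring and also moves it to a different ring position, so the compounds shown cannot separate the nitro group itself from its placement. A comparison with 4-nitrophenyl and with a phenyl ring carrying an amine at the same position as the nitro group would help to show which feature goes with the higher number.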